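Fluoro in Place of Methoxy: Estimating Compound 4

The source may hold more compounds than are shown below. What is called first, only, known or untested is meant among the compounds shown, and "the series" means these compounds.

Measured compounds:
Compound 1, `COc1ccc2c(c1NS(C)(=O)=O)CCCC2c1c[nH]cn1`, gives 501 nM in an assay on isolated protein for binding affinity to Alpha-1A adrenergic receptor (Rattus norvegicus), read by radioligand binding; a lower number here means a stronger inhibitor, a higher number a weaker inhibitor.
Compound 2, `CCS(=O)(=O)Nc1cc(Cl)cc2c1CCCC2c1c[nH]cn1`, gives 45.7 nM in this assay.
Compound 3, `COc1ccc(NS(C)(=O)=O)c2c1C(c1c[nH]cn1)CCC2`, gives 1700 nM in this assay.

Among these three, compound 3 stands at the highest number, so it is the weakest binder of the set; compound 1 sits at a lower number, and compound 2 at the lowest by a wide margin, both gaps lying beyond the usual scatter.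

Compound 4, `CS(=O)(=O)Nc1ccc(F)c2c1CCCC2c1c[nH]cn1`, has not yet been measured. It differs from compound 3 in one place: fluoro in place of methoxy on an aromatic carbon. Among the compounds with values here, no pair of measured compounds differing only in this way exists here, so no step can be read from the numbers. Compound 2 carries a halogen and binds strongly, but it differs from compound 3 in more than one place, so its value alone cannot carry the expectation. A modest improvement is expected, with a 2.1-fold lower number from compound 3 to compound 4 (0.33 log units; beyond the scatter) as the estimated step. Compound 4 is expected to give about 800 nM, in a range from 200 nM to 3000 nM.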

Compound 4, inhibition constant: 309 nM
The estimate for compound 4 lay 2.6-fold (0.41 log units) above the measured number; the measured number falls inside the stated range.
By their numbers in this assay, from the lowest: compound 2; then compounds 4 and 1 (each within the scatter of the next); then compound 3.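

At this aromatic carbon, para to a methanesulfonamido group, fluoro in place of methoxy gives a 5.5-fold lower number from compound 3 to compound 4 (0.74 log units; beyond the scatter) in this assay. Within the data shown here, this is the first comparison in the set that changes only one place, so it shows that the group on this carbon alone can shift the number by more than the usual scatter. The methoxy that leaves has more heavy atoms and a hydrogen-bond acceptor, while the fluoro that enters has one heavy atom and no counted acceptor, but nothing measured here says which difference, if any, matters.

As far as these compounds go, whether an amine, a bromo or an ethoxy on this same carbon would give a lower or a higher number stays open. From the compounds shown here alone, it is also open whether the same change would give a similar step in compound 1, which carries its methoxy in a different place.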